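The source may hold more compounds than are shown below. What is called first, only, known or untested is meant among the compounds shown, and "the series" means these compounds.

Compound 1 `Cc1csc(NC(=O)c2cccc3[nH]c(-c4ccccn4)nc23)n1` and compound 2 `Cc1csc(NC(=O)c2cccc3[nH]c(-c4cccnc4)nc23)n1` share a core and differ only at one aromatic carbon; in an ADME assay on Vero cells (Chlorocebus sabaeus) for cytotoxicity (on this read-out higher numbers stand for lower toxicity in this test and lower numbers for higher toxicity in this test), compound 1 gives 17.7 uM and compound 2 gives 111 uM, a step of a 6.3-fold higher number from compound 1 to compound 2 (0.80 log units; beyond the scatter). Compound 3 `O=C(Nc1ccccc1)c1cccc2[nH]c(-c3ccncc3)nc12` gives 49.8 uM in this assay, the second highest of the three numbers, beyond the scatter from both of the others. Compound 4 `Cc1csc(NC(=O)c2cccc3[nH]c(-c4ccncc4)nc23)n1` is compound 3 with 4-methyl-1,3-thiazol-2-yl in place of phenyl on an amide-type nitrogen. For the measured compounds named here, no measured pair shows this exchange at the amide nitrogen, so the one measured step concerns a different position and offers no direct guide. The expectation for compound 4 is therefore an unchanged number, a 1.1-fold lower number from compound 3 to compound 4 (0.04 log units; within the scatter), with wide uncertainty: compound 4 is estimated at 45 uM, plausibly between 15 uM and 140 uM.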

Compound 4, half-maximal toxic concentration: 111 uM
Compound 4: middle estimate off by 2.5-fold (0.39 log units), on the low side, within the range that was stated.
By their numbers in this assay, from the lowest: compound 1; then compound 3; then compounds 2 and 4 (each within the scatter of the next).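

In this assay, the exchange of phenyl for 4-methyl-1,3-thiazol-2-yl on the amide-type nitrogen now has a measured size with pyridin-4-yl held fixed (a 2.2-fold higher number from compound 3 to compound 4 (0.35 log units; beyond the scatter)). With 4-methyl-1,3-thiazol-2-yl kept, pyridin-4-yl matches pyridin-3-yl (no change at the digits printed from compound 2 to compound 4 (within the scatter)) but not pyridin-2-yl (a 6.3-fold higher number from compound 1 to compound 4 (0.80 log units; beyond the scatter)), so among these three rings only pyridin-2-yl stands apart. Nothing available explains these steps. From the compounds shown here alone, whether the step from phenyl holds with pyridin-2-yl or pyridin-3-yl stays open. So does how a carboxylic acid or an amine-bearing chain on the amide-type nitrogen would compare.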